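The compounds below may be only part of what the source reports. "The series", "measured", "known", "first", "only" and "open" are said of these compounds alone.

In an ADME assay on Vero cells (Chlorocebus sabaeus) for cytotoxicity, read by MTT assay, with a stated time of 72 h (a lower number here means a stronger inhibitor, a higher number a weaker inhibitor), compound 1 (`[O-][S+](CCCCN=C=S)Cc1ccccc1`) gives 4850 nM and stands level, within the scatter, with compound 2 (`O=[N+]([O-])c1ccc(C[S+]([O-])CCCCN=C=S)cc1`) at 3360 nM and with compound 3 (`COc1ccc(C[S+]([O-])CCCCN=C=S)cc1`) at 3710 nM in the same test. Compound 4 (`[O-][S+](CCCN=C=S)Cc1ccccc1`) differs from compound 1 by a group of 3 heavy atoms (1 carbon, 1 nitrogen, 1 sulfur; no ring) in place of a group of 4 heavy atoms (2 carbon, 1 nitrogen, 1 sulfur; no ring), on a saturated chain carbon, three bonds along the chain from a sulfur on a saturated chain carbon, three bonds along the chain from a sulfur. The measured steps bear on this only indirectly, since they alter an aromatic carbon and not the chain: nitro in place of hydrogen gave a 1.4-fold lower number from compound 1 to compound 2 (0.16 log units; within the scatter) and methoxy in place of hydrogen gave a 1.3-fold lower number from compound 1 to compound 3 (0.12 log units; within the scatter) within the scatter. For the measured compounds named here, no measured pair tests the chain itself, so no step beyond the scatter and no firm direction is expected. The expected change is a 1.1-fold lower number from compound 1 to compound 4 (0.05 log units; within the scatter) and stays within the scatter. Compound 4 is estimated at about 4300 nM with an expected range from 2200 nM to 8500 nM in this test.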

Compound 4, half-maximal inhibitory concentration: 10100 nM
Beside the measured number, compound 4's estimate is 2.3-fold (0.37 log units) below it; the whole stated range lies below it.
By their numbers in this assay, from the lowest: compounds 2, 3 and 1 (each within the scatter of the next); then compound 4.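

Shortening the chain, a group of 3 heavy atoms in place of a group of 4 heavy atoms, gives a 2.1-fold higher number from compound 1 to compound 4 (0.32 log units; beyond the scatter) in this assay. For the compounds shown here, this is the only step so far beyond the scatter, though a modest one, so this saturated chain carbon, three bonds along the chain from a sulfur, responds to change where the aromatic carbon changes did not. No measurement here accounts for the shift.

On these data alone, whether a longer chain would lower the number stays open. So does the effect of an amine at this place on the chain.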